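This account rests on a few compounds, and the source may have more. Where it says the series, first, only, none or still open, it means among the compounds named here.

Two urea compounds built on a shared core have been tested in a functional assay on HepG2 cells (Homo sapiens) for inhibition, with a stated time of 72 h; on this read-out higher numbers stand for weaker inhibition and lower numbers for stronger inhibition. Compound 1 `COc1ccc(NC(=O)Nc2nc(Sc3c[nH]c4ccccc34)cc(N3CCCCC3)n2)cc1` gives 17100 nM in this assay. Compound 2 `Cc1cc(Cl)ccc1NC(=O)Nc1nc(Sc2c[nH]c3ccccc23)cc(N2CCCC2)n1` gives 7150 nM, the lower of the two numbers, and its gap to compound 1 lies beyond the usual scatter. Compound 3 `COc1ccc(NC(=O)Nc2nc(Sc3c[nH]c4ccccc34)cc(N3CCCC3)n2)cc1` has not yet been measured. Relative to compound 2 it carries 4-methoxyphenyl in place of 4-chloro-2-methylphenyl on an amide-type nitrogen. Since compound 1, which also bears the 4-methoxyphenyl group, gives the higher value 17100 nM, a modest step toward weaker inhibition is expected, a 1.7-fold higher number from compound 2 to compound 3 (0.22 log units; within the scatter). Compound 3 is therefore estimated at 12000 nM, with a range from 5000 nM to 30000 nM.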

Compound 3, half-maximal inhibitory concentration: 20300 nM
Beside the measured number, compound 3's estimate is 1.7-fold (0.23 log units) below it; low and high end bracket the measured number.
By their numbers in this assay, from the lowest: compound 2; then compounds 1 and 3 (each within the scatter of the next).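

In this assay, 4-methoxyphenyl in place of 4-chloro-2-methylphenyl on the amide-type nitrogen gives a 2.8-fold higher number from compound 2 to compound 3 (0.45 log units; beyond the scatter) and so provides the first single-change reading showing that this group matters. Pyrrolidin-1-yl in place of piperidin-1-yl on an aromatic carbon gives a 1.2-fold higher number from compound 1 to compound 3 (0.07 log units; within the scatter) and so does not separate these two rings when 4-methoxyphenyl is present. No supporting data explain either step.

A 4-chlorophenyl or 2-methylphenyl group on the same nitrogen could show whether the chlorine or the methyl matters more. Going by these compounds, whether the two rings also match alongside 4-chloro-2-methylphenyl remains open.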